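Swapping the Aryl Group on the Triazole Nitrogen

A few compounds are considered here, and "the series" means these few. Any claim that something is new, unique, unknown or untested is made for them only; others in the source may bear on it.

Compound 1 `N#Cc1ccccc1-n1cc(COc2cccc(NC(=O)Nc3ccc(Cl)c(C(F)(F)F)c3)c2)nn1` gives the lowest of three numbers in a functional assay on HepG2 cells (Homo sapiens) for inhibition, read by MTT assay, with a stated time of 72 h (on this read-out higher numbers stand for weaker inhibition and lower numbers for stronger inhibition), at 1970 nM. Its two measured neighbours sit within the scatter of it: compound 2 `N#Cc1ccc(-n2cc(COc3cccc(NC(=O)Nc4ccc(Cl)c(C(F)(F)F)c4)c3)nn2)cc1` gives 2980 nM and compound 3 `CC(C)c1cccc(-n2cc(COc3cccc(NC(=O)Nc4ccc(Cl)c(C(F)(F)F)c4)c3)nn2)c1` gives 3250 nM. The steps of a 1.5-fold higher number from compound 1 to compound 2 (0.18 log units; within the scatter) and a 1.6-fold higher number from compound 1 to compound 3 (0.22 log units; within the scatter) both lie within the scatter, as does a 1.1-fold higher number from compound 2 to compound 3 (0.04 log units; within the scatter). Compound 4 `O=C(Nc1cccc(OCc2cn(-c3ccc(Cl)cc3)nn2)c1)Nc1ccc(Cl)c(C(F)(F)F)c1` differs from compound 1 in one place: 4-chlorophenyl in place of 2-cyanophenyl on an aromatic nitrogen. Because the steps of a 1.5-fold higher number from compound 1 to compound 2 (0.18 log units; within the scatter) and a 1.6-fold higher number from compound 1 to compound 3 (0.22 log units; within the scatter) moved the number only within the scatter when the group on that aromatic nitrogen was exchanged, no step beyond the scatter is expected for compound 4 in this assay. Compound 4 is therefore estimated at 2500 nM, with a range of 1000 nM to 6000 nM. That estimate means an expected step of a 1.3-fold higher number from compound 1 to compound 4 (0.10 log units; within the scatter).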

Compound 4, half-maximal inhibitory concentration: 2490 nM
Beside the measured number, compound 4's estimate is 1.0-fold (0.00 log units) above it, and the stated range covers the measured number.
By their numbers in this assay, from the lowest: compounds 1, 4, 2 and 3 (each within the scatter of the next).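

In this assay the step of a 1.3-fold higher number from compound 1 to compound 4 (0.10 log units; within the scatter) stays small, as do a 1.3-fold lower number from compound 3 to compound 4 (0.12 log units; within the scatter) and a 1.2-fold lower number from compound 2 to compound 4 (0.08 log units; within the scatter) for the direct exchange of chloro for cyano on an aromatic carbon. Compound 4 carries no nitrile, so among these four compounds a nitrile on the aryl group is not needed to keep the number in this range. No measurement shown explains this flat picture. Still open, on these data alone, is whether an amine or a carboxylic acid on the phenyl ring, or a plain alkyl chain in place of the aryl group, would move the number beyond the scatter.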